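Benzyloxyanilino series: nitro for trifluoromethyl at compound 4

The source may hold more compounds than are shown below. What is called first, only, known or untested is meant among the compounds shown, and "the series" means these compounds.

Measured so far:
- compound 1, `c1ccc(COc2ccccc2Nc2ncnc3cc4c(cc23)OCCOCCO4)cc1`, 93700 nM
- compound 2, `FC(F)(F)c1ccc(COc2ccccc2Nc2ncnc3cc4c(cc23)OCCOCCOCCO4)cc1`, > 100000 nM
- compound 3, `FC(F)(F)c1ccc(COc2cccc(Nc3ncnc4cc5c(cc34)OCCOCCOCCOCCO5)c2)cc1`, 8560 nM

All three were run in a functional assay on SH-SY5Y cells (Homo sapiens) for antiproliferative activity, read by MTT assay, with a stated time of 72 h; on this read-out higher numbers stand for weaker inhibition and lower numbers for stronger inhibition. For compound 2 the result is a limit of the assay rather than a number (the limit of > 100000 nM in this assay, at which 1 of the 3 values shown sits). Among the two numbers, compound 3 stands lowest; the nearest, compound 1, sits higher in this assay, a gap beyond the usual scatter. For the measured compounds named here, no pair of measured compounds differs in a single place, so no step has been measured directly.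

The next compound, compound 4 `O=[N+]([O-])c1ccc(COc2cccc(Nc3ncnc4cc5c(cc34)OCCOCCOCCOCCO5)c2)cc1`, differs from compound 3 by nitro in place of trifluoromethyl on an aromatic carbon, that is, 4-(trifluoromethyl)benzyl goes to 4-nitrobenzyl. Nothing measured in the series speaks to such an exchange. The expected step of a 1.1-fold higher number from compound 3 to compound 4 (0.02 log units; within the scatter) is therefore none beyond the scatter. Compound 4 is expected to give 9000 nM, estimated between 3000 nM and 30000 nM.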

Compound 4, half-maximal inhibitory concentration: 8420 nM
For compound 4 the middle estimate is 1.1-fold (0.03 log units) above the measured one; the range from low to high includes it.
By their numbers in this assay, from the lowest: compounds 4 and 3 (each within the scatter of the next); then compound 1. At a limit, above all of these: compound 2.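

In this assay the series gains its first comparison in a single place: a 1.0-fold lower number from compound 3 to compound 4 (0.01 log units; within the scatter), with the benzyloxy group and the shared core unchanged. At this position on the benzyl ring, 4-(trifluoromethyl)benzyl and 4-nitrobenzyl are therefore not told apart by this read-out, even though the exchange replaces a group with 0 hydrogen-bond acceptors by one with 2. No measurement at hand explains why the two groups read alike.

On these data alone, whether an amine, a carboxylic acid or a plain hydrogen at this place would give a similar number remains open. Also open, as far as these compounds go, is whether nitro and trifluoromethyl would still read alike on the core of compound 1 or compound 2, and how far the differences among compounds 1, 2 and 3 trace to any one structural feature.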